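Adding Fluoro to the Piperidin-1-yl Analogue

The source may report more compounds than this note shows. Statements on the series, on what has been measured and on what is new or still open speak of the compounds shown alone.

Compound 1 `COc1cc2c(Oc3ccc(NC(=O)c4nn(-c5ccccc5)c(=O)c5ccccc45)cc3F)ccnc2cc1OCCCN1CCCC1` gives 480 nM in a functional assay on NCI-H460 cells (Homo sapiens) for cytotoxicity, read by MTT assay, with a stated time of 72 h; on this read-out lower numbers stand for stronger inhibition and higher numbers for weaker inhibition. Compound 2 `COc1cc2c(Oc3ccc(NC(=O)c4nn(-c5ccccc5F)c(=O)c5ccccc45)cc3F)ccnc2cc1OCCCN1CCCC1` differs from it by fluoro in place of hydrogen on an aromatic carbon and gives 230 nM in this assay, a step of a 2.1-fold lower number from compound 1 to compound 2 (0.32 log units; beyond the scatter). Compound 3 `COc1cc2c(Oc3ccc(NC(=O)c4nn(-c5ccccc5)c(=O)c5ccccc45)cc3F)ccnc2cc1OCCCN1CCCCC1` gives 650 nM in this assay, a step of a 1.4-fold higher number from compound 1 to compound 3 (0.13 log units; within the scatter). Compound 4 `COc1cc2c(Oc3ccc(NC(=O)c4nn(-c5ccccc5F)c(=O)c5ccccc45)cc3F)ccnc2cc1OCCCN1CCCCC1` is not yet measured; it stands to compound 3 as compound 2 stands to compound 1, the difference being (fluoro in place of hydrogen on an aromatic carbon). The two cores differ by piperidin-1-yl in place of pyrrolidin-1-yl on a saturated chain carbon, three bonds along the chain from an oxygen on an aromatic ring. The surroundings of the place are described in the same words in both pairs, so this is the same kind of change. Because the earlier instance gave a 2.1-fold lower number from compound 1 to compound 2 (0.32 log units; beyond the scatter), compound 4 is expected to show a step of a 2.1-fold lower number from compound 3 to compound 4 (0.32 log units; beyond the scatter) in this assay, with an estimated value of 310 nM and a likely range from 150 nM to 650 nM.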

Compound 4, half-maximal inhibitory concentration: 160 nM
Compound 4: middle estimate off by 1.9-fold (0.29 log units), on the high side, within the range that was stated.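

The fluoro change gave a 4.1-fold lower number from compound 3 to compound 4 (0.61 log units; beyond the scatter) in this assay, so it carried over to the core of compound 3 in the same direction, and its larger size there is no real difference from the earlier step: the same change on two cores in this assay, a 2.1-fold lower number (0.32 log units; beyond the scatter) from compound 1 to compound 2 and a 4.1-fold lower number (0.61 log units; beyond the scatter) from compound 3 to compound 4, 1.9-fold (0.29 log units) apart, within the scatter of two such steps

Piperidin-1-yl in place of pyrrolidin-1-yl gave a 1.4-fold lower number from compound 2 to compound 4 (0.16 log units; within the scatter), which agrees with the same exchange on the other core: the same change on two cores in this assay, a 1.4-fold higher number (0.13 log units; within the scatter) from compound 1 to compound 3 and a 1.4-fold lower number (0.16 log units; within the scatter) from compound 2 to compound 4, 1.9-fold (0.29 log units) apart, within the scatter of two such steps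

These pairs show that the two changes carry over between these two cores only, and they do not show that either would hold on any other core.

The compounds shown leave open whether chloro or methoxy in place of fluoro would give a like step. They also leave open whether morpholin-4-yl or dimethylamino at the chain end would match pyrrolidin-1-yl and piperidin-1-yl.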